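Compound 3 to compound 4: leaving the amide link

A few compounds are considered here, and "the series" means these few. Any claim that something is new, unique, unknown or untested is made for them only; others in the source may bear on it.

Among the measured compounds shown here, in a functional assay on HepG2 cells (Homo sapiens) for inhibition, read by MTT assay, with a stated time of 48 h (a lower number here means a stronger inhibitor, a higher number a weaker inhibitor), compound 3 (`COc1ccc(N(C)c2nc(C)nc3ccccc23)cc1C(=O)NCC[Se]C#N`) gives 179 nM, the lowest number of the three measured so far. In this assay, compound 1 (`COc1ccc(N(C)c2nc(C)nc3ccccc23)cc1OCCC[Se]C#N`) gives 1040 nM, and compound 2 (`COc1ccc(N(C)c2nc(C)nc3ccccc23)cc1OCCCCCC[Se]C#N`) gives 4890 nM.

Compound 4 (`COc1ccc(N(C)c2nc(C)nc3ccccc23)cc1OCCCC[Se]C#N`), not yet measured, carries a group of 8 heavy atoms (5 carbon, 1 nitrogen, 1 oxygen, 1 selenium; no ring) in place of a group of 8 heavy atoms (4 carbon, 2 nitrogen, 1 oxygen, 1 selenium; no ring), on an aromatic carbon. The site is ortho to a methoxy group and meta to a large group. The amide-linked chain of compound 3 gives way to a chain attached through oxygen, the linkage also found in compound 1 and compound 2.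

For the measured compounds named here, three measured steps bear on this change. The modest 5.8-fold lower number from compound 1 to compound 3 (0.76 log units; beyond the scatter) and the large 27-fold lower number from compound 2 to compound 3 (1.44 log units; beyond the scatter) both enter the amide-linked chain from an oxygen-linked one, so the reverse change is expected to raise the number. The modest 4.7-fold higher number from compound 1 to compound 2 (0.67 log units; beyond the scatter) shows that chain length also counts among the oxygen-linked compounds. The chain of compound 4 is longer than that of compound 1 and shorter than that of compound 2, so a rise between the sizes of those two steps to compound 3 is expected. The expected change is an 11-fold higher number from compound 3 to compound 4 (1.03 log units; beyond the scatter), beyond the scatter. Compound 4 is estimated at 1900 nM, with an expected range of 800 nM to 4800 nM.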

Compound 4, half-maximal inhibitory concentration: 6460 nM
Compound 4: middle estimate off by 3.4-fold (0.53 log units), on the low side; the whole stated range lies below it.
By their numbers in this assay, from the lowest: compound 3; then compound 1; then compounds 2 and 4 (each within the scatter of the next).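

In this assay, the step of a 36-fold higher number from compound 3 to compound 4 (1.56 log units; beyond the scatter) is the largest listed in the series, and it comes with the heavy-atom count of the group unchanged at 8, so the size of that group alone does not set the number at this position. The entering chain attached through oxygen has 0 hydrogen-bond donors and no double bond, against 1 hydrogen-bond donor and 1 double bond in the amide-linked group, but no measurement here ties the step to either feature. Among the oxygen-linked compounds, the step of a 6.2-fold higher number from compound 1 to compound 4 (0.79 log units; beyond the scatter) lies beyond the scatter while the step of a 1.3-fold higher number from compound 2 to compound 4 (0.12 log units; within the scatter) lies within it, so the number does not keep following chain length across compound 1, compound 4 and compound 2.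

Compound 3 is the only amide-linked compound shown, so it remains open whether a shorter or longer chain on the amide link would follow the oxygen-linked pattern. As far as these compounds go, it also remains open whether the carbonyl or the amide hydrogen accounts for the difference, a question that an ester link or an amide with a methyl group on its nitrogen would address.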